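The compounds below may be only part of what the source reports. "The series", "measured", "known", "first", "only" and "open" are said of these compounds alone.

For the measured compounds named here, compound 2 `CCCCCOc1nc(N)c2nc(O)n(Cc3ccccc3)c2n1` gives 0.3 mg/kg in a functional assay on the whole organism for activation, with Mus musculus as the target (a lower number here means that less compound is needed, a higher number that more compound is needed for the effect), the only number among the two measured compounds. Compound 1 `Nc1nc(SCc2ccccc2)nc2c1nc(O)n2Cc1ccccc1` reaches only the limit > 1 mg/kg in this assay. Compound 3 `CCCOc1nc(N)c2nc(O)n(Cc3ccccc3)c2n1` has not yet been measured; it differs from compound 2 by hydrogen in place of ethyl on a saturated chain carbon, three bonds along the chain from an oxygen on an aromatic ring. Going by the values given here, the single measured step, an at least 3.3-fold lower number from compound 1 to compound 2 (0.52 log units; beyond the scatter), swaps a different group and so does not bear directly on shortening the chain. With no guide from the measured compounds, the estimate for compound 3 is 0.5 mg/kg, with a range from 0.15 mg/kg to 2 mg/kg. The step of a 1.7-fold higher number from compound 2 to compound 3 (0.22 log units; within the scatter) is thus expected to stay within the scatter.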

Compound 3, minimum effective dose: 0.3 mg/kg
The estimate for compound 3 lay 1.7-fold (0.22 log units) above the measured number; low and high end bracket the measured number.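

Hydrogen in place of ethyl on the chain, which turns pentyl into propyl, gives no change at the digits printed from compound 2 to compound 3 (within the scatter) in this assay, so this shortening of the chain costs nothing measurable. Propoxy in place of benzylsulfanyl gives an at least 3.3-fold lower number from compound 1 to compound 3 (0.52 log units; beyond the scatter), so the gain over compound 1 does not depend on having the full pentyl chain. Compound 1 carries a limit, not a number: the limit of > 1 mg/kg in this assay, at which 1 of the 3 values shown sits.

Still open, from the compounds shown here alone, is how far the chain can shrink, as with ethoxy or methoxy, and whether an amine on the same aromatic carbon would serve as well as the oxygen-linked chains.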